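Urea series: aryl swap on the amide nitrogen and solubility

The compounds below may be only part of what the source reports. "The series", "measured", "known", "first", "only" and "open" are said of these compounds alone.

Two compounds of the series have numbers in a physicochemical assay for solubility, at pH 7.4; a higher number here means a more soluble compound, a lower number a less soluble compound. Compound 1 `COc1ccc(NC(=O)Nc2cc(C)nc3ccccc23)cc1` gives 19800 nM in this assay. Compound 2 `Cc1cc(NC(=O)Nc2cccc(Cl)c2)c2ccccc2n1` gives 800 nM in this assay, the lowest of the two numbers; the gap to compound 1 lies beyond the scatter. Among the measured compounds shown here, no step between measured compounds that differ in one place is available, so the comparison rests on these two values alone.

Compound 3 `Cc1cc(NC(=O)Nc2ccc(F)cc2)c2ccccc2n1` is not yet measured. It differs from compound 2 in one place: 4-fluorophenyl in place of 3-chlorophenyl on an amide-type nitrogen. Without a matched step to lean on, the expectation for this assay is a modest rise, beyond the scatter but well short of the gap to compound 1, since the number of compound 1 in this assay, 19800 nM, marks the upper end seen so far. The step from compound 2 to compound 3 is expected to be a 3.1-fold higher number from compound 2 to compound 3 (0.49 log units; beyond the scatter). For compound 3 the estimate in this assay is 2500 nM, with a range from 800 nM to 8000 nM.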

Compound 3, solubility: 3700 nM
For compound 3 the middle estimate is 1.5-fold (0.17 log units) below the measured one; low and high end bracket the measured number.
By their numbers in this assay, from the lowest: compound 2; then compound 3; then compound 1.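

Among the compounds shown here, on the amide-type nitrogen, 4-fluorophenyl in place of 3-chlorophenyl gives a 4.6-fold higher number from compound 2 to compound 3 (0.67 log units; beyond the scatter) in this assay, the first matched reading at this position, and it shows that this aryl swap alone, with the shared core unchanged, moves the number beyond the scatter. Fluoro in place of methoxy on an aromatic carbon gives a 5.4-fold lower number from compound 1 to compound 3 (0.73 log units; beyond the scatter), which places compound 3 between compound 2 and compound 1 and shows that a single change on this aryl ring can move the number in either direction. Nothing measured here explains either step.

The step from compound 2 to compound 3 changes both the halogen and its place on the ring, so the two contributions remain inseparable. Going by these compounds, a 4-chlorophenyl group on the same nitrogen would separate them, and how an amine on this aryl ring would read remains open.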